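The source may hold more compounds than are shown below. What is called first, only, known or untested is meant among the compounds shown, and "the series" means these compounds.

Measured so far in an in vitro assay on cells for inhibition of Amine oxidase [flavin-containing] B (Homo sapiens), read by Amplex Red, with a stated time of 15 min; a higher number here means a weaker inhibitor, a lower number a stronger inhibitor:
compound 1 `O=C(/C=C/C=C/c1ccccc1)c1cc(Cl)ccc1O` gives 54.8 nM;
compound 2 `O=C(/C=C/C=C/c1ccc(Cl)cc1)c1cc(Cl)ccc1O` gives 1460 nM;
compound 3 `O=C(/C=C/C=C/c1ccc([N+](=O)[O-])cc1)c1cc(Cl)ccc1O` gives 1080 nM.

From compound 2 to compound 1 the change is hydrogen in place of chloro on an aromatic carbon, and it gave a 27-fold lower number from compound 2 to compound 1 (1.43 log units; beyond the scatter). The cores of compound 2 and compound 3 differ by nitro in place of chloro on an aromatic carbon, a step of a 1.4-fold lower number from compound 2 to compound 3 (0.13 log units; within the scatter). Compound 4 `O=C(/C=C/C=C/c1ccc([N+](=O)[O-])cc1)c1ccccc1O` is not yet measured; it differs from compound 3 by hydrogen in place of chloro on an aromatic carbon. This is the same kind of change as from compound 2 to compound 1, not the same: there the place was para to a large group, here it is meta to a large group and para to a hydroxy group. For the measured compounds named here, the step of a 1.8-fold lower number from compound 3 to compound 4 (0.26 log units; within the scatter) is expected to be smaller than the earlier one, because the only measured precedent, a 27-fold lower number from compound 2 to compound 1 (1.43 log units; beyond the scatter), concerns a different place. Compound 4 is estimated at 600 nM, between 150 nM and 2500 nM.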

Compound 4, half-maximal inhibitory concentration: 160 nM
The estimate for compound 4 lay 3.8-fold (0.57 log units) above the measured number; measured number inside the range.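

Replacing chloro with hydrogen again gave a lower number in this assay, with a 6.8-fold lower number from compound 3 to compound 4 (0.83 log units; beyond the scatter), so the direction of the change held in both cases shown. Its size did not carry over from one core to the other: the same change on two cores in this assay, a 27-fold lower number (1.43 log units; beyond the scatter) from compound 2 to compound 1 and a 6.8-fold lower number (0.83 log units; beyond the scatter) from compound 3 to compound 4, 3.9-fold (0.60 log units) apart, beyond the scatter of two such steps

The two steps differ in the core and also in where the chloro sat, here meta to a large group and para to a hydroxy group, so these compounds cannot show which of the two sets the size, and two cases make no general rule.

Still open, going by these compounds, is how a methoxy group or an amine in place of the nitro of compound 4 would compare. Also open, on these data alone, is whether a fluoro in place of the chloro would give a step in the same direction.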